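Cyclopropyl in place of 2-(trifluoromethyl)phenyl on a carbonyl carbon

The source may hold more compounds than are shown below. What is called first, only, known or untested is meant among the compounds shown, and "the series" means these compounds.

- compound 1 `COc1ccc(-c2cn3cc(C4=CCN(C(=O)c5ccccc5C(F)(F)F)CC4)ccc3n2)cc1OC`: 2550 nM
- compound 2 `COc1ccc(-c2cn3cc(C4=CCN(C(=O)C(C)(C)C)CC4)ccc3n2)cc1OC`: 4340 nM

In a functional assay on A549 cells (Homo sapiens) for antiproliferative activity, read by MTT assay, with a stated time of 48 h (on this read-out lower numbers stand for stronger inhibition and higher numbers for weaker inhibition), compound 1 has a single measured neighbour, compound 2, and the two values lie within the scatter of each other. Compound 3 `COc1ccc(-c2cn3cc(C4=CCN(C(=O)C5CC5)CC4)ccc3n2)cc1OC` follows from compound 1 by the change (cyclopropyl in place of 2-(trifluoromethyl)phenyl on a carbonyl carbon), which puts cyclopropyl in place of 2-(trifluoromethyl)phenyl on a carbonyl carbon. For the measured compounds named here, the only measured step that bears on this is a 1.7-fold higher number from compound 1 to compound 2 (0.23 log units; within the scatter), where tert-butyl enters at that same carbonyl carbon. On that evidence, no step beyond the scatter is expected in this assay. The expected step is a 1.5-fold higher number from compound 1 to compound 3 (0.17 log units; within the scatter). Compound 3 is estimated at 3800 nM, with an expected range of 1500 nM to 9500 nM.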

Compound 3, half-maximal inhibitory concentration: 9140 nM
Estimate against measurement, compound 3: 2.4-fold (0.38 log units) below; measured number inside the range.
By their numbers in this assay, from the lowest: compounds 1 and 2 (each within the scatter of the next); then compound 3.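

In this assay, the group on this carbonyl carbon turns out to matter beyond the scatter: cyclopropyl gives a 3.6-fold higher number from compound 1 to compound 3 (0.55 log units; beyond the scatter), and set against tert-butyl it gives a 2.1-fold higher number from compound 2 to compound 3 (0.32 log units; beyond the scatter). Although 2-(trifluoromethyl)phenyl and tert-butyl could not be told apart in compound 1 and compound 2, cyclopropyl stands apart from both, though only modestly. Nothing measured here explains this difference.

As far as these compounds go, it remains open whether an unsubstituted phenyl, an amine or a longer chain at this carbonyl carbon would stay with compound 1 and compound 2 or go the way of compound 3.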